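Three ketone variants on one shared core

A few compounds are considered here, and "the series" means these few. Any claim that something is new, unique, unknown or untested is made for them only; others in the source may bear on it.

Among the compounds with values here, compound 2 `CC(=O)/C=C1/C(=O)N2[C@@H]1SC(C)(C)[C@@H]2C(=O)OC(c1ccccc1)c1ccccc1` gives 63000 nM in a functional assay on A-375 cells (Homo sapiens) for cytotoxicity, read by MTT assay, with a stated time of 48 h (a lower number here means a stronger inhibitor, a higher number a weaker inhibitor), the higher of the two numbers measured so far. Its nearest neighbour, compound 1 `CC1(C)S[C@@H]2/C(=C\C(=O)c3ccco3)C(=O)N2[C@H]1C(=O)OC(c1ccccc1)c1ccccc1`, gives 26000 nM in this assay. Within the data shown here, the single measured step, a 2.4-fold higher number from compound 1 to compound 2 (0.38 log units; beyond the scatter), sets methyl in place of furan-2-yl on the carbonyl carbon. Compound 3 `CC1(C)S[C@@H]2/C(=C\C(=O)c3ccc(Br)cc3)C(=O)N2[C@H]1C(=O)OC(c1ccccc1)c1ccccc1` carries the change (4-bromophenyl in place of methyl on a carbonyl carbon), which cut one bond further out reads acetyl to (4-bromophenyl)carbonyl. The step between compound 1 and compound 2 bears on it because a 2.4-fold higher number from compound 1 to compound 2 (0.38 log units; beyond the scatter) also trades an aromatic ring against a methyl at that carbonyl carbon. Compound 3 is therefore expected to move back toward a lower number in this assay, by a step of roughly that size in the reverse direction, a 2.9-fold lower number from compound 2 to compound 3 (0.46 log units; beyond the scatter). Resting on one step only, the estimate for compound 3 is 22000 nM, within 7000 nM to 65000 nM.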

Compound 3, half-maximal inhibitory concentration: 29700 nM
Compound 3: the middle estimate sits 1.4-fold (0.13 log units) below what was measured; the range from low to high includes it.
By their numbers in this assay, from the lowest: compounds 1 and 3 (each within the scatter of the next); then compound 2.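

In this assay a second aromatic group now stands against methyl on the carbonyl carbon, and the step reads a 2.1-fold lower number from compound 2 to compound 3 (0.33 log units; beyond the scatter) in the same direction as the step from methyl to furan-2-yl. Setting 4-bromophenyl in place of furan-2-yl gives a 1.1-fold higher number from compound 1 to compound 3 (0.06 log units; within the scatter) and so shows no difference between these two aromatic groups. At this position the only separation seen so far is between methyl and either ring, and both steps behind it are modest.

On these data alone, whether a saturated ring such as cyclohexyl or a longer chain in place of methyl would fall with compound 2 or with the two aromatic compounds remains open, as does the effect of an amine in place of the bromine of compound 3. Nothing available gives a reason for these differences.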